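The compounds below may be only part of what the source reports. "The series", "measured", "known", "first", "only" and "open" are said of these compounds alone.

Measured so far in a functional assay on SiHa cells (Homo sapiens) for antiproliferative activity, read by CCK-8 assay, with a stated time of 72 h; on this read-out higher numbers stand for weaker inhibition and lower numbers for stronger inhibition:
- compound 1 `COc1ccc(-c2cncnc2-c2cc(OC)c(OC)c(OC)c2)cc1` gives 2850 nM
- compound 2 `COc1ccc(-c2cncnc2-c2cc(OC)c(OC)c(OC)c2)cc1Cl` gives 1330 nM
- compound 3 `COc1cc(-c2ncncc2-c2ccc(SC)cc2)cc(OC)c1OC` gives 560 nM

Not yet measured: compound 4 `CCSc1ccc(-c2cncnc2-c2cc(OC)c(OC)c(OC)c2)cc1`

Compound 3 stands lowest of the measured set at 560 nM in this assay and so shows the strongest inhibition so far. The change under review is methyl in place of hydrogen on a saturated chain carbon bound to a sulfur and reads methyl in place of hydrogen on a saturated chain carbon bound to a sulfur, or methylsulfanyl to ethylsulfanyl. For the measured compounds named here, no measured step alters this chain, so the evidence is indirect. The closest is a 5.1-fold lower number from compound 1 to compound 3 (0.71 log units; beyond the scatter) with methylsulfanyl in place of methoxy, a modest step. The steps of a 2.1-fold lower number from compound 1 to compound 2 (0.33 log units; beyond the scatter) and a 2.4-fold lower number from compound 2 to compound 3 (0.38 log units; beyond the scatter) are also modest but involve other changes. With the exchange of methoxy for methylsulfanyl giving only a 5.1-fold lower number from compound 1 to compound 3 (0.71 log units; beyond the scatter) as its step, the added methyl is expected to give a small shift, most likely within the scatter and leaning towards a higher number. The expected step is a 1.3-fold higher number from compound 3 to compound 4 (0.10 log units; within the scatter) and would not exceed the scatter. For compound 4 the estimated value is 700 nM with an expected range from 300 nM to 1600 nM in this series.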

Compound 4, half-maximal inhibitory concentration: 1030 nM
Compound 4: middle estimate off by 1.5-fold (0.17 log units), on the low side, and the stated range covers the measured number.
By their numbers in this assay, from the lowest: compounds 3, 4 and 2 (each within the scatter of the next, the first and the last beyond it); then compound 1.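

In this assay, for the compounds shown here, the added methyl on the saturated chain carbon bound to a sulfur gives a 1.8-fold higher number from compound 3 to compound 4 (0.26 log units; within the scatter) and is the first measured change to this chain, so the step from methylsulfanyl to ethylsulfanyl is not resolved from the scatter here. The ethylsulfanyl group still gives a 2.8-fold lower number from compound 1 to compound 4 (0.44 log units; beyond the scatter) against methoxy, while a 1.3-fold lower number from compound 2 to compound 4 (0.11 log units; within the scatter) leaves compound 4 within the scatter of the chloro-bearing compound 2. No measurement at hand gives a cause for these steps.

Open, from the compounds shown here alone, is whether a propylsulfanyl or isopropylsulfanyl group would stay within the scatter of compound 3, and whether a chain ending in an amine or a carboxylic acid would be accepted. Also open, going by these compounds, is how chloro and ethylsulfanyl would act together on one compound.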